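The source may report more compounds than this note shows. Statements on the series, on what has been measured and on what is new or still open speak of the compounds shown alone.

Of the compounds shown here, three have been measured.
Compound 1 `COc1ccc(CCCN2CCC(COC(c3ccccc3)c3ccc(Cl)cc3)CC2)cc1` gives 200 nM in a functional assay on cells (T-cell line, Homo sapiens) for inhibition; on this read-out lower numbers stand for stronger inhibition and higher numbers for weaker inhibition.
Compound 3 `Clc1ccc(CCCN2CCC(COC(c3ccccc3)c3ccccc3)CC2)cc1` gives 500 nM in this assay.
Compound 2 `CN1CCC(COC(c2ccccc2)c2ccccc2)CC1` gives only a limit of the assay in this assay, > 20000 nM.

On the numbers shown, compound 2 therefore stands at the edge of what this assay reports: the limit of > 20000 nM in this assay, at which 1 of the 3 values shown sits, and no number of its own is known for it. Compound 4 `CCCCCCCCN1CCC(COC(c2ccccc2)c2ccccc2)CC1` differs from compound 2 in one place: heptyl in place of hydrogen on a saturated chain carbon bound to an amine nitrogen in a ring. Within the data shown here, only one measured step bears on this change, the enlargement at the same place that gave an at least 40-fold lower number from compound 2 to compound 3 (1.60 log units; beyond the scatter). That entering group, 2-(4-chlorophenyl)ethyl, carries a ring; the heptyl group entering in compound 4 carries none, so compound 3 is an imperfect guide. Still, a step in the same direction, toward a lower number, is expected for compound 4, estimated as an at least 10-fold lower number from compound 2 to compound 4 (1.00 log units; beyond the scatter), smaller than the step seen with compound 3. For compound 4 the estimated result in this assay is 2000 nM, with a range from 500 nM to 10000 nM.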

Compound 4, half-maximal inhibitory concentration: 700 nM
Beside the measured number, compound 4's estimate is 2.9-fold (0.46 log units) above it, within the range that was stated.
By their numbers in this assay, from the lowest: compound 1; then compounds 3 and 4 (each within the scatter of the next). At a limit, above all of these: compound 2.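

Heptyl in place of hydrogen at this place gives, in this assay, an at least 28-fold lower number from compound 2 to compound 4 (1.45 log units; beyond the scatter), so the large step seen earlier does not require a ring in the entering group. Pentyl in place of 4-chlorophenyl gives a 1.4-fold higher number from compound 3 to compound 4 (0.15 log units; within the scatter), so on this read-out compound 3 and compound 4 cannot be told apart, and at this place the chain without a ring serves as well as the one ending in 4-chlorophenyl. Compound 2 stands at a limit of the assay, so both large steps from it are bounds and not exact sizes: the limit of > 20000 nM in this assay, at which 1 of the 4 values shown sits.

Going by these compounds, whether a shorter chain such as butyl would give a similar value remains open. So does whether a hydroxyl group or a carboxylic acid carried on the heptyl chain would keep it.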